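Chloro for trifluoromethyl on the pyridine-side ring of compound 1

This account rests on a few compounds, and the source may have more. Where it says the series, first, only, none or still open, it means among the compounds named here.

Measured compounds:
compound 1 `O=C(Nc1ccc(Cl)cc1)C1=CCN(c2ncccc2C(F)(F)F)CC1` 19 nM
compound 2 `O=C(Nc1ccc(C(F)(F)F)cc1)C1=CCN(c2ncccc2C(F)(F)F)CC1` 8 nM

In an in vitro functional assay on 1321-N1 cells for antagonist activity at transient receptor potential cation channel subfamily V member 1 (Homo sapiens), read by FLIPR and calcium flux (on this read-out lower numbers stand for stronger inhibition and higher numbers for weaker inhibition), compound 1 gives the higher of the two numbers; compound 2 sits a 2.4-fold lower number from compound 1 to compound 2 (0.38 log units; beyond the scatter) away. Compound 3 `O=C(Nc1ccc(Cl)cc1)C1=CCN(c2ncccc2Cl)CC1` is not yet measured. It differs from compound 1 by chloro in place of trifluoromethyl on an aromatic carbon. Within the data shown here, the only measured step, a 2.4-fold lower number from compound 1 to compound 2 (0.38 log units; beyond the scatter), concerns the other aromatic ring and the opposite exchange, so it bears on this change only loosely. Among the measured compounds shown here, no step on the ring with one nitrogen is known. A modest weakening, or no step beyond the scatter, is expected: compound 3 is estimated at 35 nM (range 12 nM to 100 nM), a step of a 1.8-fold higher number from compound 1 to compound 3 (0.27 log units; within the scatter).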

Compound 3, half-maximal inhibitory concentration: 33 nM
For compound 3 the middle estimate is 1.1-fold (0.03 log units) above the measured one; low and high end bracket the measured number.
By their numbers in this assay, from the lowest: compound 2; then compounds 1 and 3 (each within the scatter of the next).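

In this assay, among these compounds, the step of a 1.7-fold higher number from compound 1 to compound 3 (0.24 log units; within the scatter) gives the first reading at this position on the six-membered aromatic ring with 1 nitrogen: trifluoromethyl and chloro cannot be told apart here, with the rest of compound 1 held constant. Trifluoromethyl is therefore not needed at this carbon to keep the activity of compound 1. No measurement on these compounds offers a reason for this.

Still open, going by these compounds, is how chloro here behaves with the other aromatic ring of compound 2, and whether a methoxy group or an amine on this carbon would keep the activity.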